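The source may hold more compounds than are shown below. What is called first, only, known or untested is meant among the compounds shown, and "the series" means these compounds.

Measured compounds:
Compound 1, `Oc1nc2nonc2nc1Nc1ccccc1F`, gives 12500 nM.
Compound 2, `CCc1ccc(Nc2nc3nonc3nc2O)c(F)c1`, gives 6700 nM.
Compound 3, `CCCCCc1ccc(Nc2nc3nonc3nc2O)c(F)c1`, gives 1500 nM.

These three values come from an assay on mitochondria from L6 cells (Rattus norvegicus) for activation, with a stated time of 90 min; a higher number here means that more compound is needed for the effect, a lower number that less compound is needed. Compound 1 stands highest of the three; compound 2 is nearest to it, with a 1.9-fold lower number from compound 1 to compound 2 (0.27 log units; within the scatter), and compound 3 is furthest, with an 8.3-fold lower number from compound 1 to compound 3 (0.92 log units; beyond the scatter). Between them lies a 4.5-fold lower number from compound 2 to compound 3 (0.65 log units; beyond the scatter), so the two steps that go beyond the scatter both add a chain to the ring that carries the fluoro.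

Compound 4, `Oc1nc2nonc2nc1Nc1ccccc1C(F)(F)F`, is not yet measured. It differs from compound 1 by trifluoromethyl in place of fluoro on an aromatic carbon. No measured step touches that place: the chain steps add carbon at another aromatic carbon, and nothing shown exchanges the fluoro itself. The chain steps suggest that added carbon on this ring can lower the number in this assay, but the exchange in compound 4 is smaller and sits elsewhere, so a step no larger than the scatter, or a small lowering, is expected. For compound 4 the expected value in this assay is 8000 nM, within 3000 nM to 25000 nM, which is expected to amount to a 1.6-fold lower number from compound 1 to compound 4 (0.19 log units; within the scatter).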

Compound 4, half-maximal effective concentration: 10600 nM
Compound 4: middle estimate off by 1.3-fold (0.12 log units), on the low side, and the stated range covers the measured number.
By their numbers in this assay, from the lowest: compound 3; then compounds 2, 4 and 1 (each within the scatter of the next).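

In this assay, trifluoromethyl in place of fluoro on the aromatic carbon ortho to a large group gives a 1.2-fold lower number from compound 1 to compound 4 (0.07 log units; within the scatter) and so no change that can be told from the scatter. This position therefore carries 4 heavy atoms instead of 1 heavy atom with no step beyond the scatter, whereas the pentyl addition elsewhere on the ring gave an 8.3-fold lower number from compound 1 to compound 3 (0.92 log units; beyond the scatter) as its larger step. Nothing available explains why the exchange leaves the number in place. The compounds shown leave open whether an amine or a carboxylic acid at this position would move the number. They also leave open whether a pentyl chain would lower the number to the same extent with trifluoromethyl on the ring in place of fluoro.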